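1,3-Thiazol-5-yl in place of 1,2,4-thiadiazol-5-yl

A few compounds are considered here, and "the series" means these few. Any claim that something is new, unique, unknown or untested is made for them only; others in the source may bear on it.

Measured so far in an ADME assay on liver (Homo sapiens) for metabolic stability, read by LC-MS, using microsomes and NADPH, with a stated time of 40 min, tested at 1 uM; a higher number here means faster removal of the compound, a lower number slower removal:
- compound 1 `COc1cc(C(F)(F)F)ccc1-c1cccc2cc(S(=O)(=O)Nc3ncns3)ccc12`: 15 mL.min-1.g-1
- compound 2 `COc1cc(C(F)(F)F)ccc1-c1cccc2cc(S(=O)(=O)Nc3ccncn3)ccc12`: < 14 mL.min-1.g-1 (a limit of the assay)

Going by the values given here, compound 1 holds the only actual number in this assay, so it cannot yet be placed within a range of values. The result for compound 2, < 14 mL.min-1.g-1, is a limit. Compound 3 `COc1cc(C(F)(F)F)ccc1-c1cccc2cc(S(=O)(=O)Nc3cncs3)ccc12` differs from compound 1 by 1,3-thiazol-5-yl in place of 1,2,4-thiadiazol-5-yl on a sulfonamide nitrogen. Among the compounds with values here, the one measured step at this sulfonamide nitrogen is an at least 1.0-fold lower number from compound 1 to compound 2 (0.02 log units; that floor lies within the scatter), with pyrimidin-4-yl replacing 1,2,4-thiadiazol-5-yl. It is a different replacement, and its floor lies within the scatter, so it gives only weak guidance and sets no direction. The expected change is a 1.1-fold higher number from compound 1 to compound 3 (0.03 log units; within the scatter), which is estimated to stay within the scatter. For compound 3 the estimate is 16 mL.min-1.g-1, with an expected range of 10 mL.min-1.g-1 to 32 mL.min-1.g-1.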

Compound 3, intrinsic clearance in microsomes: 46 mL.min-1.g-1
Compound 3: middle estimate off by 2.9-fold (0.46 log units), on the low side; the whole stated range lies below it.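

Going by these compounds alone, replacing 1,2,4-thiadiazol-5-yl with 1,3-thiazol-5-yl on the sulfonamide nitrogen gives, in this assay, a 3.1-fold higher number from compound 1 to compound 3 (0.49 log units; beyond the scatter), the first step at this position that clearly lies beyond the scatter. Against pyrimidin-4-yl the change gives an at least 3.2-fold higher number from compound 2 to compound 3 (0.51 log units; beyond the scatter), so compound 3 shows the fastest removal of the three. The result for compound 2 is a limit of the assay, which makes that step a floor whose full size cannot be read: the limit of < 14 mL.min-1.g-1 in this assay, at which 1 of the 3 values shown sits.

Going by these compounds, whether the higher number follows from the one ring nitrogen fewer in 1,3-thiazol-5-yl or is particular to this ring remains open, as a single pair cannot separate the two. On these data alone, how this read-out responds to an open alkyl chain or to a ring carrying an amine on the sulfonamide nitrogen also remains open.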